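A few compounds are considered here, and "the series" means these few. Any claim that something is new, unique, unknown or untested is made for them only; others in the source may bear on it.

Measured compounds in a physicochemical assay for lipophilicity, read by HPLC, measured as octanol-water partition; a higher number here means a more lipophilic compound, a lower number a more polar compound:
- compound 1 `O=C1O[C@@H](CN2CCC(O)CC2)CN1c1ccc(-n2cc(-c3ccccn3)cn2)c(F)c1` gives 1.63
- compound 2 `O=C1CCC(=O)N1C[C@H]1CN(c2ccc(-n3cc(-c4ccccn4)cn3)c(F)c2)C(=O)O1` gives 1.58
- compound 3 `COC[C@H]1CN(c2ccc(-n3cc(-c4ccccn4)cn3)c(F)c2)C(=O)O1` gives 2.18

Compound 1 stands second highest of the three. Its nearest neighbour is compound 2, with a step of a number 0.05 log units lower from compound 1 to compound 2 (within the scatter); the furthest is compound 3, with a step of a number 0.55 log units higher from compound 1 to compound 3 (beyond the scatter). Between the two other compounds the step is a number 0.60 log units higher from compound 2 to compound 3 (beyond the scatter).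

Compound 4 `O=CNC[C@H]1CN(c2ccc(-n3cc(-c4ccccn4)cn3)c(F)c2)C(=O)O1` is not yet measured. Its difference from compound 1 is formylamino in place of 4-hydroxypiperidin-1-yl on a saturated chain carbon bound to a saturated ring carbon.

Two measured steps from compound 1 bear on this change, both replacing the same group at the same place. Exchange for 2,5-dioxopyrrolidin-1-yl gave a number 0.05 log units lower from compound 1 to compound 2 (within the scatter), within the scatter; exchange for methoxy gave a number 0.55 log units higher from compound 1 to compound 3 (beyond the scatter), a modest rise. Formylamino carries one hydrogen-bond donor and one acceptor, as the leaving group does, and is smaller than either tried replacement. The step in this assay is therefore expected to be small, at most within or barely beyond the scatter, and if anything downward rather than upward: the estimated step is a number 0.18 log units lower from compound 1 to compound 4 (within the scatter). For compound 4 the expected value is 1.45, with a range from 0.95 to 1.95.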

Compound 4, partition coefficient: 1.19
Estimate against measurement, compound 4: 0.26 log units above; the measured number falls inside the stated range.
By their numbers in this assay, from the lowest: compound 4; then compounds 2 and 1 (each within the scatter of the next); then compound 3.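

In this assay, formylamino on this saturated chain carbon gives the lowest number of the four compounds, with a number 0.44 log units lower from compound 1 to compound 4 (beyond the scatter), a number 0.39 log units lower from compound 2 to compound 4 (beyond the scatter) and a number 0.99 log units lower from compound 3 to compound 4 (beyond the scatter). This position therefore moves the number in both directions from compound 1: methoxy takes it up and formylamino takes it down, so two groups much smaller than 4-hydroxypiperidin-1-yl lie at opposite ends of the series. The data shown hold no measurement that accounts for this fall.

The compounds shown leave open whether the low number depends on the amide hydrogen of formylamino or on the formyl carbonyl, a question that acetylamino and N-methylformylamino at this carbon would address. Where a primary amine or a carboxylic acid on a longer chain would fall at this place also remains open.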